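Hydroxyalkyl urea tail: from compound 2 to compound 3

The source may hold more compounds than are shown below. What is called first, only, known or untested is meant among the compounds shown, and "the series" means these compounds.

In a physicochemical assay for inhibition, read by spectrophotometry, tested at 100 uM (on this read-out lower numbers stand for less inhibition and higher numbers for more inhibition at the one concentration tested (going by the name of the read-out)), compound 1 `COc1cc(NC(C)CCCNC(=O)NNC(=O)NCCCCCO)c2ncccc2c1` gives 54% and compound 2 `COc1cc(NC(C)CCCNC(=O)NNC(=O)NC(CO)(CO)CO)c2ncccc2c1` gives 49%. Compound 2 stands at the lower of the two numbers shown, compound 1 being its only neighbour, and the step between them is small: a number 5 percentage points lower from compound 1 to compound 2 (within the scatter). Compound 3 `COc1cc(NC(C)CCCNC(=O)NNC(=O)NCCCO)c2ncccc2c1` is not yet measured; against compound 2 the change is 3-hydroxypropyl in place of 2-hydroxy-1,1-bis(hydroxymethyl)ethyl on an amide-type nitrogen. Within the data shown here, the one measured step at this amide-type nitrogen is the step from compound 1 to compound 2, which was small, so the expected step of a number 3 percentage points higher from compound 2 to compound 3 (within the scatter) in this assay is none beyond the scatter. Compound 3 is therefore estimated at 52%, with a range of 38% to 66%.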

Compound 3, a percentage reported as inhibition, at one concentration (the size of the read-out at that concentration, not a potency): 45%
For compound 3 the middle estimate is 7 percentage points above the measured one; the range from low to high includes it.
By their numbers in this assay, from the lowest: compounds 3, 2 and 1 (each within the scatter of the next).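

At this amide-type nitrogen, this assay gives a number 4 percentage points lower from compound 2 to compound 3 (within the scatter), so the exchange of 2-hydroxy-1,1-bis(hydroxymethyl)ethyl for 3-hydroxypropyl also stays within the scatter. The chain comparison gives a number 9 percentage points lower from compound 1 to compound 3 (within the scatter), so 3-hydroxypropyl, 5-hydroxypentyl and 2-hydroxy-1,1-bis(hydroxymethyl)ethyl are not told apart by this read-out. No supporting evidence bears on this result. Still open, on these data alone, is whether a tail ending in an amine or a carboxylic acid, or a longer chain, would give a step beyond the scatter. Also open, as far as these compounds go, is whether these compounds would separate at another concentration.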